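The source may report more compounds than this note shows. Statements on the series, on what has been measured and on what is new or still open speak of the compounds shown alone.

Among the compounds with values here, in a functional assay on A549 cells (Homo sapiens) for antiproliferative activity, read by WST assay, with a stated time of 72 h (a lower number here means that less compound is needed, a higher number that more compound is needed for the effect), compound 1 (`CCCCCCNCC(=O)Nc1ccc(/C(N)=N/O)cc1`) gives 658000 nM, the only actual number so far. Compound 2 (`CCCCCCNC(=O)Nc1ccc(/C(N)=N/O)cc1`) reads > 1000000 nM, which is a limit of the assay and not a number. Compound 3 (`CCCCNCCC(=O)Nc1ccc(/C(N)=N/O)cc1`) keeps the core of compound 1 and has (butylamino)methyl in place of hexylamino on a saturated chain carbon bound to a carbonyl carbon. Within the data shown here, no measured pair covers this change, so the expectation rests on compound 1 alone, at 658000 nM. In this assay, no shift beyond the usual scatter is expected, and no direction can be argued with confidence. The expected change, a 1.1-fold higher number from compound 1 to compound 3 (0.06 log units; within the scatter), is therefore small. For compound 3 the estimated value is 750000 nM, with an expected range of 320000 nM to 1600000 nM.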

Compound 3, half-maximal effective concentration: 881000 nM
Compound 3: middle estimate off by 1.2-fold (0.07 log units), on the low side, and the stated range covers the measured number.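

The exchange of hexylamino for (butylamino)methyl on a saturated chain carbon bound to a carbonyl carbon now has a measured step in this assay: a 1.3-fold higher number from compound 1 to compound 3 (0.13 log units; within the scatter). This position therefore tolerates this particular exchange without a shift beyond the scatter, and compound 1 and compound 3 cannot be ordered, although the entering and leaving groups differ in their atoms and not in their counted hydrogen-bond donors and acceptors. Compound 2 stands at a limit and not at a number, so it adds no step: the limit of > 1000000 nM in this assay, at which 1 of the 3 values shown sits.

Within the data shown here, whether any group at this place can move the number beyond the scatter remains open, since the only readable step joins two open-chain amines. A longer chain such as octylamino, a piperidine ring or a carboxylic acid at this place would test that.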